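The source may hold more compounds than are shown below. What is called first, only, known or untested is meant among the compounds shown, and "the series" means these compounds.

Measured compounds and values in an assay on CHO cells for displacement of a labelled ligand from adenosine receptor A1 (Homo sapiens), read by scintillation counting, with a stated time of 3 h; a lower number here means a stronger inhibitor, a higher number a weaker inhibitor:

compound 1 `CCn1c(-c2ccccc2)nc2c(NC3CCCCC3)ncnc21`: 10 nM
compound 2 `Cn1c(-c2ccccc2)nc2c(NC3CCCCC3)ncnc21`: 5.7 nM
compound 3 `CCCn1c(-c2ccccc2)nc2c(NC3CCCCC3)ncnc21`: 27 nM

Compound 2 shows the lowest of the three numbers. Its nearest neighbour is compound 1, with a 1.8-fold lower number from compound 1 to compound 2 (0.24 log units; within the scatter), so the two cannot be told apart. Compound 3 is furthest away, with a 4.7-fold higher number from compound 2 to compound 3 (0.68 log units; beyond the scatter), and compound 1 to compound 3 gives a 2.7-fold higher number from compound 1 to compound 3 (0.43 log units; beyond the scatter). All three measured steps concern the saturated chain bound to the aromatic nitrogen of the shared core; the amine substituent is cyclohexyl throughout.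

Compound 4 `Cn1c(-c2ccccc2)nc2c(NC3CCOC3)ncnc21` departs from compound 2 at that amine: oxolan-3-yl in place of cyclohexyl on a nitrogen on an aromatic ring. For the measured compounds named here, no measured step touches this position, so none of the three steps bears directly on the change, and the expectation must rest on the change itself rather than on a precedent from this set. A ring of different size and composition at the amine is taken as more likely to weaken than to improve binding, so a modest rise in the number is expected, with a wide range to reflect the absence of any relevant step. Compound 4 is therefore estimated at 60 nM in this assay, between 15 nM and 250 nM, meaning an expected step of an 11-fold higher number from compound 2 to compound 4 (1.02 log units; beyond the scatter).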

Compound 4, inhibition constant: 8 nM
Compound 4: middle estimate off by 7.5-fold (0.88 log units), on the high side; measured number below the stated range.
By their numbers in this assay, from the lowest: compounds 2, 4 and 1 (each within the scatter of the next); then compound 3.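

In this assay, for the compounds shown here, the amine substituent changes for the first time, and oxolan-3-yl in place of cyclohexyl on a nitrogen on an aromatic ring gives a 1.4-fold higher number from compound 2 to compound 4 (0.15 log units; within the scatter), so the two compounds cannot be told apart. This position therefore accepts a move from 6 heavy atoms, all carbon, to 5 heavy atoms including 1 oxygen, and from 0 hydrogen-bond acceptors to 1, with no change that can be read, while the chain on the aromatic nitrogen gave a 4.7-fold higher number from compound 2 to compound 3 (0.68 log units; beyond the scatter) on going from methyl to propyl in the same series. No measurement on hand offers an explanation for this result.

As far as these compounds go, the change alters ring size and ring composition together, so the separate contributions remain open; cyclopentyl at the amine would bear on ring size alone, and oxan-4-yl on the oxygen in a six-membered ring. Also open, from the compounds shown here alone, is whether oxolan-3-yl behaves in the same way when ethyl or propyl, rather than methyl, sits on the aromatic nitrogen, and how a basic group such as a piperidin-4-yl amine would fare at this position.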